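Dropping the Chlorine from a Long Amide Chain

A few compounds are considered here, and "the series" means these few. Any claim that something is new, unique, unknown or untested is made for them only; others in the source may bear on it.

Compound 1 `COc1ccc(CN(C(=O)C2CC2)c2cc(OC)c(OC)c(OC)c2)cc1O` gives 80 nM in a functional assay on KYSE-450 cells (Homo sapiens) for inhibition, read by MTT assay, with a stated time of 48 h; a higher number here means a weaker inhibitor, a lower number a stronger inhibitor.
Compound 2 `COc1ccc(CN(C(C)=O)c2cc(OC)c(OC)c(OC)c2)cc1O` gives 160 nM in this assay.
Compound 3 `COc1ccc(CN(C(=O)CCCCCl)c2cc(OC)c(OC)c(OC)c2)cc1O` gives 770 nM in this assay.

Compound 3 has the highest number of the three: the steps of a 9.6-fold higher number from compound 1 to compound 3 (0.98 log units; beyond the scatter) and a 4.8-fold higher number from compound 2 to compound 3 (0.68 log units; beyond the scatter) both lie beyond the scatter, so compound 3 is the weakest inhibitor of this set. Compound 4 `CCCCC(=O)N(Cc1ccc(OC)c(O)c1)c1cc(OC)c(OC)c(OC)c1` differs from compound 3 only at the far end of the chain: hydrogen in place of chloro on a saturated chain carbon, four bonds along the chain from a carbonyl carbon.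

Within the data shown here, none of the measured steps removes a chlorine. The two that touch this chain, a 4.8-fold higher number from compound 2 to compound 3 (0.68 log units; beyond the scatter) and a 9.6-fold higher number from compound 1 to compound 3 (0.98 log units; beyond the scatter), show that the 4-chlorobutyl chain arrived together with a loss of potency, but they do not tell how much of that loss travels with the chlorine itself and how much with the chain. Compound 4 keeps the full chain length, so only a small change in this assay is expected, probably within the scatter, leaning slightly toward a lower number.

Compound 4 is therefore expected to give 600 nM, somewhere between 250 nM and 1500 nM. That estimate corresponds to an expected step of a 1.3-fold lower number from compound 3 to compound 4 (0.11 log units; within the scatter).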

Compound 4, half-maximal inhibitory concentration: 300 nM
Compound 4: middle estimate off by 2.0-fold (0.30 log units), on the high side, and the stated range covers the measured number.
By their numbers in this assay, from the lowest: compounds 1, 2 and 4 (each within the scatter of the next, the first and the last beyond it); then compound 3.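

Taking away the one chlorine atom at the end of the chain is enough to shift the result in this assay (a 2.6-fold lower number from compound 3 to compound 4 (0.41 log units; beyond the scatter)), so part of the potency lost with the 4-chlorobutyl chain goes with the chlorine and not with the chain length. The plain chain still differs by the reference chosen: propyl in place of hydrogen on the carbon bound to the carbonyl stays within the scatter (a 1.9-fold higher number from compound 2 to compound 4 (0.27 log units; within the scatter)), whereas butyl in place of cyclopropyl on the carbonyl carbon lies beyond it (a 3.8-fold higher number from compound 1 to compound 4 (0.57 log units; beyond the scatter)). Nothing shown gives a reason for the effect of the chlorine. From the compounds shown here alone, whether a fluorine, a hydroxyl or an amine at the chain end would behave like hydrogen or like chloro remains open. So does the result for a longer chain, or for a carboxylic acid at the end of the butyl chain.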